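Cyclopropyl to Oxolan-2-yl Amide, Tried on a Second Core

The compounds below may be only part of what the source reports. "The series", "measured", "known", "first", "only" and "open" are said of these compounds alone.

Measured so far in an assay on CHO cells for displacement of a labelled ligand from histamine receptor H3 (Macaca mulatta); a higher number here means a weaker inhibitor, a lower number a stronger inhibitor:
compound 1 `CC1CCCN1C1CCN(c2ccc(NC(=O)C3CC3)cc2)C1` gives 9.7 nM
compound 2 `CC1CCCN1C1CCN(c2ccc(NC(=O)C3CCCO3)cc2)C1` gives 8.7 nM
compound 3 `Cc1cc(NC(=O)C2CC2)ccc1N1CCC(N2CCCC2C)C1` gives 17.7 nM

Compound 1 and compound 2 differ in one place, (oxolan-2-yl in place of cyclopropyl on a carbonyl carbon). This change produced a 1.1-fold lower number from compound 1 to compound 2 (0.05 log units; within the scatter), so the two amide groups gave numbers that cannot be told apart. Compound 3 carries a different core: it differs from compound 1 by methyl in place of hydrogen on an aromatic carbon, and that change gave a 1.8-fold higher number from compound 1 to compound 3 (0.26 log units; within the scatter).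

Compound 4 `Cc1cc(NC(=O)C2CCCO2)ccc1N1CCC(N2CCCC2C)C1` has not yet been measured in this assay. It differs from compound 3 by oxolan-2-yl in place of cyclopropyl on a carbonyl carbon, the same change that turned compound 1 into compound 2, at the same kind of position. Because the first instance gave a 1.1-fold lower number from compound 1 to compound 2 (0.05 log units; within the scatter), the expectation is that the second instance behaves alike, with a step of about a 1.1-fold lower number from compound 3 to compound 4 (0.04 log units; within the scatter) from compound 3 to compound 4. Going by the values given here, only one prior example exists, so the range is kept wide. The estimate for compound 4 in this assay is 16 nM, from 7 nM to 36 nM.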

Compound 4, inhibition constant: 17 nM
Compound 4: middle estimate off by 1.1-fold (0.03 log units), on the low side; low and high end bracket the measured number.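

The swap of cyclopropyl for oxolan-2-yl on the carbonyl carbon carried over to the methyl-bearing core in this assay, giving a 1.0-fold lower number from compound 3 to compound 4 (0.02 log units; within the scatter) and matching the earlier step: the same change on two cores in this assay, a 1.1-fold lower number (0.05 log units; within the scatter) from compound 1 to compound 2 and a 1.0-fold lower number (0.02 log units; within the scatter) from compound 3 to compound 4, 1.1-fold (0.03 log units) apart, within the scatter of two such steps. Methyl in place of hydrogen on an aromatic carbon carried over in the same way, giving a 2.0-fold higher number from compound 2 to compound 4 (0.29 log units; within the scatter) on the core with the oxolan-2-yl amide: the same change on two cores in this assay, a 1.8-fold higher number (0.26 log units; within the scatter) from compound 1 to compound 3 and a 2.0-fold higher number (0.29 log units; within the scatter) from compound 2 to compound 4, 1.1-fold (0.03 log units) apart, within the scatter of two such steps. Both changes therefore behaved alike on the two cores shown, but the amide swap left the number unmoved on each, and these two pairs of compounds do not show that the same would hold on any other core or in any other assay.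

The compounds shown leave open whether a larger change on the carbonyl carbon, such as a phenyl ring, an amine or a longer chain, would move the number. They also leave open whether chlorine in place of the methyl on the aromatic carbon would behave as the methyl does.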